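The source may report more compounds than this note shows. Statements on the series, on what has been measured and on what is new or still open speak of the compounds shown alone.

Values in a functional assay on L6 cells (Rattus norvegicus) for cytotoxicity; a lower number here means a stronger inhibitor, a higher number a weaker inhibitor:
- compound 1 `Nc1nc(N)nc(N/N=C/c2cccs2)n1`: 78200 nM
- compound 2 `CNc1nc(NC)nc(N/N=C/c2ccc([N+](=O)[O-])o2)n1`: 44100 nM
- compound 3 `Nc1nc(N)nc(N/N=C/c2ccco2)n1`: > 400000 nM (a limit)

Compound 2 at 44100 nM and compound 1 at 78200 nM lie within the scatter of each other, so neither ranks ahead. Compound 3 reads > 400000 nM, which is a limit of the assay and not a number.

Compound 4 `CNc1nc(N)nc(N/N=C/c2ccc([N+](=O)[O-])o2)n1` is reached by a single change, (hydrogen in place of methyl on a nitrogen on an aromatic ring), that is, hydrogen in place of methyl on a nitrogen on an aromatic ring, or methylamino to amino. For the measured compounds named here, no measured step makes this change. Going by the values given here, the only measured step, an at least 5.1-fold higher number from compound 1 to compound 3 (0.70 log units; beyond the scatter), is furan-2-yl in place of thiophen-2-yl, a different place and a different kind of change, so it gives no size to carry over.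

The expectation therefore rests on compound 2 at 44100 nM itself. In this assay, the step of a 1.1-fold higher number from compound 2 to compound 4 (0.05 log units; within the scatter) is expected to stay within the scatter, with no direction favoured, though the uncertainty is wide. For compound 4 the estimated value is 50000 nM, with an expected range from 15000 nM to 170000 nM.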

Compound 4, half-maximal inhibitory concentration: 48900 nM
For compound 4 the middle estimate is 1.0-fold (0.01 log units) above the measured one; measured number inside the range.
By their numbers in this assay, from the lowest: compounds 2, 4 and 1 (each within the scatter of the next). At a limit, above all of these: compound 3.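

In this assay, for the compounds shown here, the change of methylamino to amino gives a 1.1-fold higher number from compound 2 to compound 4 (0.04 log units; within the scatter), the first measured step at this place, a nitrogen on an aromatic ring. Going by these compounds alone, the one earlier step concerned furan-2-yl and thiophen-2-yl, so it said nothing about this nitrogen. In this pair, the methyl on this nitrogen can be replaced by hydrogen with no readable shift in the number, although compound 4 still carries one methylamino group.

On these data alone, whether replacing that remaining methyl by hydrogen would also leave the number within the scatter stays open, as does the outcome with an ethyl group or a longer chain on this nitrogen. Compound 3 stays a limit and not a number, and this holds for the series as shown: the limit of > 400000 nM in this assay, at which 1 of the 4 values shown sits.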